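The compounds below may be only part of what the source reports. "The series", "measured", "known", "first", "only" and "open" are said of these compounds alone.

In an ADME assay on the whole organism (Mus musculus, strain Swiss Webster) for pharmacokinetics, read by LC-MS, at a dose of 50 mg/kg by the oral route (a lower number here means less compound in the circulation, a higher number more compound in the circulation at the dose given), compound 1 `O=C(Nc1ccc(F)c(-c2nc3ncc(-c4ccc(F)c(F)c4)cc3[nH]2)c1)N1CCCC1` gives 12000 ng.h/mL and compound 2 `O=C(Nc1ccc(F)c(-c2nc3ncc(-c4cncc(F)c4)cc3[nH]2)c1)N1CCCC1` gives 1560 ng.h/mL. Compound 3 `O=C(Nc1ccc(F)c(-c2nc3ncc(-c4cccc(F)c4F)cc3[nH]2)c1)N1CCCC1`, which shares their core and carries 2,3-difluorophenyl, gives 4750 ng.h/mL, the second highest of the three numbers. Its place is fixed by two measured steps: a 2.5-fold lower number from compound 1 to compound 3 (0.40 log units; beyond the scatter) and a 3.0-fold higher number from compound 2 to compound 3 (0.48 log units; beyond the scatter).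

Compound 4 `O=C(Nc1ccc(F)c(-c2nc3ncc(-c4cccc(F)c4)cc3[nH]2)c1)N1CCCC1` differs from compound 3 by one small edit: hydrogen in place of fluoro on an aromatic carbon, which turns 2,3-difluorophenyl into 3-fluorophenyl (hydrogen in place of fluoro on an aromatic carbon). Going by the values given here, no measured pair shows this edit alone, so the guidance is indirect. The two steps above swap the whole group on that same carbon, and the widest swap is a 7.7-fold lower number from compound 1 to compound 2 (0.89 log units; beyond the scatter). All three are modest, and none shows what removing a single fluoro does, so the data give no direction. A step smaller than these swaps is expected, and the estimate is a 1.1-fold lower number from compound 3 to compound 4 (0.02 log units; within the scatter). For compound 4 the estimated value is 4500 ng.h/mL, with an expected range from 1800 ng.h/mL to 11000 ng.h/mL.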

Compound 4, area under the concentration-time curve: 15000 ng.h/mL
Estimate against measurement, compound 4: 3.3-fold (0.52 log units) below; measured number above the stated range.
By their numbers in this assay, from the lowest: compound 2; then compound 3; then compounds 1 and 4 (each within the scatter of the next).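

In this assay, a single fluoro on this ring can clearly move the number: going from 2,3-difluorophenyl to 3-fluorophenyl, which removes the fluoro ortho to a large group, gives a 3.2-fold higher number from compound 3 to compound 4 (0.50 log units; beyond the scatter). The same kind of edit starting from 3,4-difluorophenyl gives a 1.3-fold higher number from compound 1 to compound 4 (0.10 log units; within the scatter), so in these compounds it matters which fluoro leaves, not only how many remain. Replacing 5-fluoropyridin-3-yl with 3-fluorophenyl gives a 9.6-fold higher number from compound 2 to compound 4 (0.98 log units; beyond the scatter), which shows that the all-carbon ring with one fluoro is far from equivalent to its pyridine counterpart here.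

Nothing in hand explains why losing this fluoro changes the number. Going by these compounds, it also remains open how a chloro or methoxy group on that carbon would compare with hydrogen, and how a plain phenyl with no fluoro would behave.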